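The compounds below may be only part of what the source reports. "The series", "measured", "known", "first", "only" and "open" are said of these compounds alone.

For the measured compounds named here, compound 3 `Nc1sc(-c2ccc(Cl)cc2)c(-c2ccc(Cl)cc2)c1C(=O)NC1CC1` gives the lowest of the three numbers measured so far in a functional assay on PC-3 cells (Homo sapiens) for inhibition, read by sulforhodamine B assay, with a stated time of 72 h; on this read-out lower numbers stand for stronger inhibition and higher numbers for weaker inhibition: compound 3 gives 3680 nM. The other two compounds carry different groups on the same amide-type nitrogen. Compound 1 `CC(C)(C)NC(=O)c1c(N)sc(-c2ccc(Cl)cc2)c1-c1ccc(Cl)cc1` carries tert-butyl there, and in this assay compound 1 gives 15100 nM; compound 2 `Nc1sc(-c2ccc(Cl)cc2)c(-c2ccc(Cl)cc2)c1C(=O)NC1CCCC1` carries cyclopentyl, and compound 2 gives 21200 nM. Both steps toward compound 3 lie beyond the scatter: a 4.1-fold lower number from compound 1 to compound 3 (0.61 log units; beyond the scatter) and a 5.8-fold lower number from compound 2 to compound 3 (0.76 log units; beyond the scatter). Between the other two nothing separates the numbers, since a 1.4-fold higher number from compound 1 to compound 2 (0.15 log units; within the scatter).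

Compound 4 `CC(C)CNC(=O)c1c(N)sc(-c2ccc(Cl)cc2)c1-c1ccc(Cl)cc1` has not yet been measured. The change from compound 3 is isobutyl in place of cyclopropyl on an amide-type nitrogen. The two steps that bear on it both run from another group on this nitrogen to cyclopropyl and both lowered the number, so the reverse direction, away from cyclopropyl, points toward a higher number. Isobutyl is neither tert-butyl nor cyclopentyl, and whether it behaves like them cannot be read from these three compounds alone. The expected step is a 3.0-fold higher number from compound 3 to compound 4 (0.48 log units; beyond the scatter), a rise that is expected to fall short of the earlier two. The estimate for compound 4 in this assay is 11000 nM, with a range from 4000 nM to 30000 nM.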

Compound 4, half-maximal inhibitory concentration: 13200 nM
Beside the measured number, compound 4's estimate is 1.2-fold (0.08 log units) below it; low and high end bracket the measured number.
By their numbers in this assay, from the lowest: compound 3; then compounds 4, 1 and 2 (each within the scatter of the next).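

In this assay, a 3.6-fold higher number from compound 3 to compound 4 (0.55 log units; beyond the scatter) shows that cyclopropyl on the amide-type nitrogen also keeps its advantage over an open-chain group with no branch at the nitrogen-bound carbon, a comparison that tert-butyl and cyclopentyl could not offer. Isobutyl does not separate from either of those groups, with a 1.1-fold lower number from compound 1 to compound 4 (0.06 log units; within the scatter) and a 1.6-fold lower number from compound 2 to compound 4 (0.21 log units; within the scatter), so among these four compounds cyclopropyl alone stands apart, and since cyclopentyl also carries a ring yet stays with the two open-chain groups, a ring on this nitrogen is not by itself enough to go with the lower number. No measurement beyond these numbers is available to account for this difference.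

The compounds shown leave open whether cyclobutyl, or a short open chain such as ethyl or methyl, would stay with cyclopropyl or fall in with the other three groups. They also do not show how a chain ending in an amine or a carboxylic acid would read on this nitrogen, or whether the cyclopropyl advantage would hold on any core other than the shared one.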